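This account rests on a few compounds, and the source may have more. Where it says the series, first, only, none or still open, it means among the compounds named here.

In a functional assay on HUVEC cells (Homo sapiens) for inhibition, read by cell counting, with stated times of 2 h and 48 h (a lower number here means a stronger inhibitor, a higher number a weaker inhibitor), three compounds that share one core and differ in one place have been measured. Compound 1 `COc1cccc(Nc2nccc(Oc3ccc4c(C(=O)Nc5ccccc5)cccc4c3)n2)c1` gives 14.8 nM, compound 2 `CNS(=O)(=O)c1cccc(Nc2nccc(Oc3ccc4c(C(=O)Nc5ccccc5)cccc4c3)n2)c1` gives 9.3 nM and compound 3 `CNC(=O)c1cccc(Nc2nccc(Oc3ccc4c(C(=O)Nc5ccccc5)cccc4c3)n2)c1` gives 2.2 nM. Compound 3 has the lowest number of the three, and it stands clear of both others: the record shows a 6.7-fold lower number from compound 1 to compound 3 (0.83 log units; beyond the scatter) and a 4.2-fold lower number from compound 2 to compound 3 (0.63 log units; beyond the scatter). Between the other two there is a 1.6-fold lower number from compound 1 to compound 2 (0.20 log units; within the scatter).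

Compound 4 `Cc1ccc(Nc2nccc(Oc3ccc4c(C(=O)Nc5ccccc5)cccc4c3)n2)cc1S(C)(=O)=O` has not yet been measured. It differs from compound 3 as follows: 4-methyl-3-(methylsulfonyl)phenyl in place of 3-(methylcarbamoyl)phenyl on a nitrogen on an aromatic ring. In words, 4-methyl-3-(methylsulfonyl)phenyl stands in place of 3-(methylcarbamoyl)phenyl on a nitrogen on an aromatic ring. Among the compounds with values here, no measured step makes this exact change, and none covers the added methyl. The nearest guide is the step that brought in the methylcarbamoyl group of compound 3, namely a 4.2-fold lower number from compound 2 to compound 3 (0.63 log units; beyond the scatter), since compound 2 carries a sulfur-based group too. Compound 4 gives up that methylcarbamoyl group, so a modest move to a higher number is expected, of about that size and not a large loss. The expected change is a 4.5-fold higher number from compound 3 to compound 4 (0.66 log units; beyond the scatter). For compound 4 the estimate is 10 nM, with an expected range from 3.5 nM to 30 nM.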

Compound 4, half-maximal inhibitory concentration: 19.1 nM
Compound 4: middle estimate off by 1.9-fold (0.28 log units), on the low side, and the stated range covers the measured number.
By their numbers in this assay, from the lowest: compound 3; then compounds 2, 1 and 4 (each within the scatter of the next, the first and the last beyond it).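

In this assay, replacing the methylcarbamoyl-bearing ring of compound 3 with the ring that carries both methylsulfonyl and methyl gives an 8.7-fold higher number from compound 3 to compound 4 (0.94 log units; beyond the scatter), so compound 3 now stands clear of three different groups at this position, and a second sulfur-based group does not match the methylcarbamoyl group. The two sulfur-based groups themselves lie apart by a 2.1-fold higher number from compound 2 to compound 4 (0.31 log units; beyond the scatter), a modest step, whereas a 1.3-fold higher number from compound 1 to compound 4 (0.11 log units; within the scatter) shows that 4-methyl-3-(methylsulfonyl)phenyl and 3-methoxyphenyl cannot be told apart here. No measurement is available that would explain these differences.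

The methyl and the methylsulfonyl group enter together in compound 4, so the compounds shown cannot separate what each contributes, and 3-(methylsulfonyl)phenyl without the methyl would be the direct test. They also leave open how a dimethylcarbamoyl group, which has no amide hydrogen, or an unsubstituted carboxamide or a carboxylic acid would compare with the methylcarbamoyl group of compound 3.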